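Triazine series: diisopropylamino replacing tert-butylamino at the amino carbon

The compounds below may be only part of what the source reports. "The series", "measured", "known", "first", "only" and "open" are said of these compounds alone.

Measured compounds:
compound 1, `C[C@H](Nc1nc(Cl)nc(NC(C)(C)C)n1)c1ccccc1`, 7410 nM
compound 2, `CC(C)Nc1nc(Cl)nc(N[C@H](C)c2ccccc2)n1`, 2000 nM
compound 3, `CCNc1nc(Cl)nc(NC(C)c2ccccc2)n1`, 9770 nM

All three were run in an ADME assay on the whole organism for inhibition, with Echinochloa crus-galli var. formosensis as the target, with a stated time of 4 days; a higher number here means a weaker inhibitor, a lower number a stronger inhibitor. Compound 1 gives 7410 nM, the second highest of the three numbers. Compound 3 is nearest, at 9770 nM, and the two lie within the scatter of each other, so no order between them is claimed. Compound 2, at 2000 nM, stands furthest from compound 1, with a gap beyond the scatter.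

The next compound, compound 4, is `CC(C)N(c1nc(Cl)nc(N[C@@H](C)c2ccccc2)n1)C(C)C`. Its difference from compound 1 is diisopropylamino in place of (tert-butyl)amino on an aromatic carbon. Among the compounds with values here, no measured pair in this set isolates this change, so no step between measured compounds can be quoted for it; what follows is an expectation only.

The expected step for compound 4 is a 2.0-fold higher number from compound 1 to compound 4 (0.31 log units; beyond the scatter), toward a weaker inhibitor, since the shared core is otherwise unchanged and compound 1 already gives 7410 nM. Compound 4 is thus estimated at 15000 nM, with a range of 4000 nM to 60000 nM.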

Compound 4, half-maximal inhibitory concentration: 110 nM
Compound 4: middle estimate off by 140-fold (2.13 log units), on the high side, outside the stated range (below it).
By their numbers in this assay, from the lowest: compound 4; then compound 2; then compounds 1 and 3 (each within the scatter of the next).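

Within the data shown here, changing (tert-butyl)amino to diisopropylamino on this aromatic carbon, opposite the ring nitrogen, gives a 67-fold lower number from compound 1 to compound 4 (1.83 log units; beyond the scatter) in this assay, a large move toward a stronger inhibitor that the earlier compounds gave no sign of. This position therefore accepts a group with no hydrogen-bond donor and more heavy atoms, and activity in this pair does not depend on the amino hydrogen. This single pair cannot separate the loss of that hydrogen from the gain in heavy atoms, and no measurement bearing on the reason for the step is available.

As far as these compounds go, it remains open whether other disubstituted amino groups, such as dimethylamino, diethylamino or dipropylamino, would behave like diisopropylamino at this carbon. From the compounds shown here alone, it is also open whether the step would persist if a methoxy group or a methylthio group replaced the chloro group.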